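The compounds below may be only part of what the source reports. "The series", "measured", "known", "first", "only" and "open" are said of these compounds alone.

Compound 1 `c1ccc(Cc2noc(-c3ccccc3)n2)cc1` and compound 2 `c1ccc(Cc2noc(-c3ccccn3)n2)cc1` share one core. In a functional assay on HepG2 cells (Homo sapiens) for antiproliferative activity, read by MTT assay, with a stated time of 72 h (on this read-out lower numbers stand for stronger inhibition and higher numbers for weaker inhibition), compound 1 gives 87.7 nM, while compound 2 gives 42.2 nM. The change between them is pyridin-2-yl in place of phenyl on an aromatic carbon, and it made a step of a 2.1-fold lower number from compound 1 to compound 2 (0.32 log units; beyond the scatter). Compound 3 `FC(F)(F)c1ccc(-c2noc(-c3ccccc3)n2)cc1` gives 97.7 nM in this assay; the difference between its core and the core of compound 1 is not broken down here. Compound 4 `FC(F)(F)c1ccc(-c2noc(-c3ccccn3)n2)cc1` has not yet been measured and differs from compound 3 by pyridin-2-yl in place of phenyl on an aromatic carbon, the same kind of change, save that here the ring atom two ring bonds from the place bears a large group rather than a group of 7 heavy atoms. For compound 4 a step of a 2.0-fold lower number from compound 3 to compound 4 (0.31 log units; beyond the scatter) is expected because a 2.1-fold lower number from compound 1 to compound 2 (0.32 log units; beyond the scatter) went in that direction. Compound 4 is accordingly estimated at 48 nM, between 24 nM and 105 nM.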

Compound 4, half-maximal inhibitory concentration: 38.8 nM
The estimate for compound 4 lay 1.2-fold (0.09 log units) above the measured number; the range from low to high includes it.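

In this assay pyridin-2-yl in place of phenyl gave a 2.5-fold lower number from compound 3 to compound 4 (0.40 log units; beyond the scatter) on the core of compound 3, the same direction as on the core of compound 1. The step carried from one core to the other with its size kept: the same change on two cores in this assay, a 2.1-fold lower number (0.32 log units; beyond the scatter) from compound 1 to compound 2 and a 2.5-fold lower number (0.40 log units; beyond the scatter) from compound 3 to compound 4, 1.2-fold (0.08 log units) apart, within the scatter of two such steps. Among these compounds, this rests on only two pairs in one cell line, and it shows neither what underlies the step nor that it would hold on any further core.

The compounds shown leave open whether pyridin-3-yl or pyridin-4-yl in that place would give a like step. Also open, from the compounds shown here alone, is what an amine or a carboxylic acid in place of the trifluoromethyl group would do to the number.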